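The source may report more compounds than this note shows. Statements on the series, on what has been measured and on what is new or still open speak of the compounds shown alone.

Of the compounds shown here, three have been measured in a functional assay on A549 cells (Homo sapiens) for cytotoxicity, read by MTT assay, with a stated time of 48 h; a lower number here means that less compound is needed, a higher number that more compound is needed for the effect. Compound 1 `CO[C@H]1O[C@H](COc2ccc(-c3ccccc3)cc2)[C@@H](O)[C@H](O)[C@H]1Oc1ccccc1` gives 36000 nM in this assay. Compound 2 `CO[C@H]1O[C@H](COc2ccccc2C(C)C)[C@@H](O)[C@H](O)[C@H]1Oc1ccc(OC2CCCCC2)cc1` gives 33000 nM, and compound 3 `CO[C@H]1O[C@H](COc2ccc3c(c2)CCCC3)[C@@H](O)[C@H](O)[C@H]1Oc1cccc(C(C)C)c1` gives 40000 nM. Compound 1 stands second highest of the three numbers; its nearest neighbour is compound 2 and its furthest is compound 3, and both gaps lie within the usual scatter, so the three values cannot be told apart. Compound 4 `CO[C@H]1O[C@H](COc2ccc(-c3ccccc3)cc2)[C@@H](O)[C@H](O)[C@H]1Oc1cccc(C(C)C)c1` has not yet been measured in this assay. It differs from compound 1 in one place: isopropyl in place of hydrogen on an aromatic carbon. For the measured compounds named here, no measured pair shows this change on its own, so there is no direct step to lean on. Since compounds 1, 2 and 3 all fall within the scatter of one another, no step beyond the scatter is expected in this assay, and the estimated step of no change at the digits printed from compound 1 to compound 4 (within the scatter) is small. Compound 4 is therefore expected to give about 36000 nM, within an estimated range of 16000 nM to 80000 nM.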

Compound 4, half-maximal effective concentration: 32000 nM
Beside the measured number, compound 4's estimate is 1.1-fold (0.05 log units) above it; the measured number falls inside the stated range.
By their numbers in this assay, from the lowest: compounds 4, 2, 1 and 3 (each within the scatter of the next).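

Placing isopropyl in place of hydrogen on an aromatic carbon, on the phenoxy ring and meta to a large group, gives a 1.1-fold lower number from compound 1 to compound 4 (0.05 log units; within the scatter) in this assay. For the compounds shown here, this is the first pair in which the change stands alone, and it shows that phenoxy can become 3-isopropylphenoxy on the core of compound 1 with no step beyond the scatter in this assay. Nothing measured here bears on why the number holds at this position.

The compounds shown leave open whether an amine or a carboxylic acid in place of the isopropyl would give a step beyond the scatter. They also leave open whether isopropyl placed elsewhere on this ring, or a longer chain at this same place, would do so.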